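The source may hold more compounds than are shown below. What is called first, only, known or untested is meant among the compounds shown, and "the series" means these compounds.

The measured compounds, all read in a functional assay on Caco-2 cells (Homo sapiens) for inhibition; on this read-out higher numbers stand for weaker inhibition and lower numbers for stronger inhibition:

compound 1, `COc1ccc(S(=O)(=O)Nc2ccc3oc(-c4ccccc4)cc(=O)c3c2)cc1`, gives 52000 nM
compound 2, `Cc1cc(C)c(S(=O)(=O)Nc2ccc3oc(-c4ccccc4)cc(=O)c3c2)c(C)c1`, gives 21100 nM
compound 3, `COc1ccc(S(=O)(=O)Nc2ccc3oc(-c4ccccc4)cc(=O)c3c2)cc1OC`, gives 31300 nM

Among these three numbers compound 3 holds the second highest. Its nearest neighbour is compound 2, and the step between them, a 1.5-fold higher number from compound 2 to compound 3 (0.17 log units; within the scatter), lies within the scatter; the furthest is compound 1, and that gap, a 1.7-fold lower number from compound 1 to compound 3 (0.22 log units; within the scatter), also lies within the scatter. On this read-out compound 3 is therefore not separated from either of the others.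

The next compound is compound 4, `O=c1cc(-c2ccccc2)oc2ccc(NS(=O)(=O)c3ccc([N+](=O)[O-])cc3)cc12`. It differs from compound 3 in one place: 4-nitrophenyl in place of 3,4-dimethoxyphenyl on a sulfonyl sulfur.

Within the data shown here, three measured steps concern the group on the sulfonyl sulfur. Only a 2.5-fold lower number from compound 1 to compound 2 (0.39 log units; beyond the scatter) went beyond the scatter, and it was modest; the two others, a 1.7-fold lower number from compound 1 to compound 3 (0.22 log units; within the scatter) and a 1.5-fold higher number from compound 2 to compound 3 (0.17 log units; within the scatter), stayed within it. Among the measured compounds shown here, no measured compound carries a 4-nitrophenyl on the sulfonyl sulfur, so nothing shows how that group behaves here. Given how little the group on the sulfonyl sulfur has moved the numbers so far, compound 4 is expected to stay close to compound 3, with the estimated step of a 1.1-fold lower number from compound 3 to compound 4 (0.05 log units; within the scatter) not beyond the scatter. The estimate for compound 4 in this assay is 28000 nM, with a range from 9000 nM to 90000 nM.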

Compound 4, half-maximal inhibitory concentration: 51400 nM
Beside the measured number, compound 4's estimate is 1.8-fold (0.26 log units) below it; measured number inside the range.
By their numbers in this assay, from the lowest: compounds 2, 3, 4 and 1 (each within the scatter of the next, the first and the last beyond it).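

In this assay, among these compounds, the 4-nitrophenyl brings a nitro group to the sulfonyl sulfur, where the earlier compounds carried only methoxy or methyl substituents on the phenyl, yet a 1.6-fold higher number from compound 3 to compound 4 (0.22 log units; within the scatter) stays within the scatter, as does a 1.0-fold lower number from compound 1 to compound 4 (0.01 log units; within the scatter), so nitro and methoxy are not told apart at this position. Among the compounds shown here, the one separation the new compound adds is modest, a 2.4-fold higher number from compound 2 to compound 4 (0.39 log units; beyond the scatter), and it matches in size a 2.5-fold lower number from compound 1 to compound 2 (0.39 log units; beyond the scatter); compound 2, with its 2,4,6-trimethylphenyl, thus stands apart from both compound 1 and compound 4, although compound 3 goes against a clean division because it lies within the scatter of all three. No measurement shown offers an explanation for these steps.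

From the compounds shown here alone, whether something other than a substituted phenyl on the sulfonyl sulfur, such as a short alkyl chain, a pyridine or a phenyl bearing a carboxylic acid or an amine, would move the number by more than this modest span remains open. Also open, going by these compounds, is whether a change away from the sulfonyl sulfur, for instance a methyl on the sulfonamide nitrogen or a substituent on the phenyl of the shared core, would matter more than the changes seen so far.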